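Bromo for Hydrogen on the Phenyl of Compound 3

The source may hold more compounds than are shown below. What is called first, only, known or untested is meant among the compounds shown, and "the series" means these compounds.

Of the compounds shown here, three that share one core have been measured in an ADME assay on MT2 cells (Homo sapiens) for cytotoxicity, read by XTT assay, with a stated time of 4 days; a lower number here means that less compound is tolerated, a higher number that more compound is tolerated. Compound 1 `Cc1ccc(C)n1-c1cccc(-c2nnn[nH]2)c1` gives 250000 nM. Compound 2 `CCOC(=O)/C(C#N)=C/c1cc(C)n(-c2cccc(-c3nnn[nH]3)c2)c1C` gives 76800 nM, reached by a 3.3-fold lower number from compound 1 to compound 2 (0.51 log units; beyond the scatter). Compound 3 `Cc1cc(/C=C2\SC(=S)N(c3ccccc3)C2=O)c(C)n1-c1cccc(-c2nnn[nH]2)c1` gives 61000 nM; this lies within the scatter of compound 2 and beyond the scatter below compound 1. Compound 4 `Cc1cc(/C=C2\SC(=S)N(c3cccc(Br)c3)C2=O)c(C)n1-c1cccc(-c2nnn[nH]2)c1` differs from compound 3 by bromo in place of hydrogen on an aromatic carbon. Within the data shown here, the single measured step, a 3.3-fold lower number from compound 1 to compound 2 (0.51 log units; beyond the scatter), concerns a different change and does not bear on a bromo for hydrogen exchange; no measured pair speaks to it. The change is therefore expected to give a 1.2-fold lower number from compound 3 to compound 4 (0.09 log units; within the scatter), not beyond the scatter. Compound 4 is expected at 50000 nM, with a range from 25000 nM to 100000 nM.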

Compound 4, half-maximal cytotoxic concentration: 22600 nM
Compound 4: middle estimate off by 2.2-fold (0.34 log units), on the high side, and the stated range ends above it.
By their numbers in this assay, from the lowest: compound 4; then compounds 3 and 2 (each within the scatter of the next); then compound 1.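

In this assay the position on the phenyl of compound 3 proves sensitive to substitution: bromo in place of hydrogen gives a 2.7-fold lower number from compound 3 to compound 4 (0.43 log units; beyond the scatter) and so moves the number beyond the scatter. Among these compounds, this is the first measured pair to speak to this exchange, and it shows that a single added bromine on this ring is enough to lower the tolerated concentration. Nothing measured here explains the shift.

On these data alone, whether chloro, methoxy or a carboxylic acid on the same carbon would shift the number likewise remains open. As far as these compounds go, with one pair, it also remains open whether the 3-bromophenyl step would hold on other compounds.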